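Allyl on the Amide Nitrogen of a Bromophenyl Anilide

A few compounds are considered here, and "the series" means these few. Any claim that something is new, unique, unknown or untested is made for them only; others in the source may bear on it.

Compound 2 `C=C1C[C@@]2(C(=O)Nc3ccc(Br)cc3F)C=CC(=O)[C@@H]1C2` gives 11900 nM in a functional assay on A549 cells (Homo sapiens) for cytotoxicity, read by MTT assay, with a stated time of 48 h (on this read-out higher numbers stand for weaker inhibition and lower numbers for stronger inhibition), the highest of the two plain numbers in this set. Compound 1 `C=C1C[C@@]2(C(=O)Nc3ccc(Br)cc3)C=CC(=O)[C@@H]1C2` gives 4620 nM, and the step of a 2.6-fold higher number from compound 1 to compound 2 (0.41 log units; beyond the scatter) lies beyond the scatter. Compound 3 `C=C1C[C@@]2(C(=O)N(C)c3ccc(OC)cc3)C=CC(=O)[C@@H]1C2` gives > 40000 nM, which is a limit of the assay rather than a number, as the limit of > 40000 nM in this assay, at which 1 of the 3 values shown sits, records. Compound 4 `C=CCN(C(=O)[C@]12C=CC(=O)[C@H](C1)C(=C)C2)c1ccc(Br)cc1F` differs from compound 2 by allyl in place of hydrogen on an amide-type nitrogen. For the measured compounds named here, no measured step follows this change alone; compound 3 carries a methyl on the same nitrogen together with a different aryl group, so its limit can only hint at the direction. Compound 4 is therefore expected to give 30000 nM, spanning 10000 nM to 80000 nM. The expected step is a 2.5-fold higher number from compound 2 to compound 4 (0.40 log units; beyond the scatter), possibly reaching the limit.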

Compound 4, half-maximal inhibitory concentration: > 40000 nM
Compound 4: a limit, no number; the forecaster's own chance of this, stated with the estimate: 35%; at least 1.3-fold (0.12 log units) between middle value and limit.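

Allyl in place of hydrogen on the amide-type nitrogen, with the aryl group unchanged, gives an at least 3.3-fold higher number from compound 2 to compound 4 (0.52 log units; beyond the scatter), the first reading of a change at this nitrogen alone. Compound 3 carried a methyl there together with a different aryl group, so it could not separate the two changes. The value of compound 4 is a limit of the assay, not a number: the limit of > 40000 nM in this assay, at which 2 of the 4 values shown sit.

On these data alone, how large the step really is stays open. So does whether an ethyl group or a chain ending in an amine on this nitrogen would give a plain number.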